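The source may report more compounds than this note shows. Statements on the series, on what has been measured and on what is new or still open speak of the compounds shown alone.

Measured compounds:
compound 1, `Cc1cc(-c2ccc(Cl)cc2)cc(C)c1Nc1ccnc(Nc2ccc(C#N)cc2)n1`: 4190 nM
compound 2, `Cc1cc(-c2cccc(F)c2)cc(C)c1Nc1ccnc(Nc2ccc(C#N)cc2)n1`: 4120 nM
compound 3, `Cc1ccccc1-c1cc(C)c(Nc2ccnc(Nc3ccc(C#N)cc3)n2)c(C)c1`: 3820 nM

In an ADME assay on MT4 cells (Homo sapiens) for cytotoxicity, read by MTT assay, with a stated time of 4 days (on this read-out higher numbers stand for lower toxicity in this test and lower numbers for higher toxicity in this test), the three numbers sit close together: the steps of a 1.0-fold lower number from compound 1 to compound 2 (0.01 log units; within the scatter), a 1.1-fold lower number from compound 1 to compound 3 (0.04 log units; within the scatter) and a 1.1-fold lower number from compound 2 to compound 3 (0.03 log units; within the scatter) all fall within the scatter, so compound 3 stands indistinguishable from compound 1 and compound 2. Compound 4 `Cc1cccc(-c2cc(C)c(Nc3ccnc(Nc4ccc(C#N)cc4)n3)c(C)c2)c1` differs from compound 3 by 3-methylphenyl in place of 2-methylphenyl on an aromatic carbon. Every swap of the pendant aryl ring measured so far, including the step from compound 2 to compound 3 that also moved a substituent around that ring, left this read-out unchanged beyond the scatter. The step from compound 3 to compound 4 is therefore expected to be a 1.0-fold higher number from compound 3 to compound 4 (0.01 log units; within the scatter), with no direction beyond the scatter. Compound 4 is estimated at 3900 nM, between 2000 nM and 7500 nM.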

Compound 4, half-maximal cytotoxic concentration: 3670 nM
The estimate for compound 4 lay 1.1-fold (0.03 log units) above the measured number, within the range that was stated.
By their numbers in this assay, from the lowest: compounds 4, 3, 2 and 1 (each within the scatter of the next).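

Moving the methyl group on the pendant ring, 3-methylphenyl in place of 2-methylphenyl, is the first change of a single substituent's place with the ring and group kept the same, and in this assay it stays within the scatter (a 1.0-fold lower number from compound 3 to compound 4 (0.02 log units; within the scatter)). Methyl in place of fluoro (a 1.1-fold lower number from compound 2 to compound 4 (0.05 log units; within the scatter)) and 3-methylphenyl in place of 4-chlorophenyl (a 1.1-fold lower number from compound 1 to compound 4 (0.06 log units; within the scatter)) also stay within it, so all four compounds remain indistinguishable. No measured evidence bears on this result. Going by these compounds, whether an amine or a carboxylic acid on the pendant ring would stay within the same range remains open.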